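Adding a Second Hydroxyl: What to Expect for Compound 3

The compounds below may be only part of what the source reports. "The series", "measured", "known", "first", "only" and "open" are said of these compounds alone.

Compound 1 `Oc1cccc(C2=NN(c3ccc(Cl)cc3)C(c3ccc(Cl)cc3)C2)c1` was tested in an assay on HEK293 cells for inhibition of protein kinase C zeta type (Homo sapiens), read by 33P incorporation, with a stated time of 40 min, tested at 20 uM, in the presence of a further agent that is not named here (on this read-out lower numbers stand for less inhibition and higher numbers for more inhibition at the one concentration tested (going by the name of the read-out)), and gives 69.3%. This is the higher of the two numbers at hand. Compound 2 `COc1ccc(C2=NN(c3cccc(Cl)c3)C(c3cccc(Cl)c3)C2)cc1` differs from compound 1 in several places. In this assay compound 2 gives 25.3%, a number well below that of compound 1 and beyond the usual scatter. Going by the values given here, no two measured compounds differ in a single place, so no measured step can guide a comparison.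

Compound 3 `Oc1ccc(C2=NN(c3ccc(Cl)cc3)C(c3ccc(Cl)cc3)C2)c(O)c1` has not yet been measured. It differs from compound 1 by one change: 2,4-dihydroxyphenyl in place of 3-hydroxyphenyl on a carbon with a double bond to nitrogen The shared core and both 4-chlorophenyl groups remain as they are. Among the compounds with values here, with no measured step of this kind available, the size of the change in this assay is uncertain; a modest step in either direction, or none beyond the scatter, seems plausible. Compound 3 is expected to give about 70%, within a range from 40% to 92%. The expected step of a number 0.7 percentage points higher from compound 1 to compound 3 (within the scatter) is small, in keeping with compound 1 already standing at 69.3%.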

Compound 3, a percentage reported as inhibition, at one concentration (the size of the read-out at that concentration, not a potency): 71.1%
Compound 3: the middle estimate sits 1.1 percentage points below what was measured; the range from low to high includes it.
By their numbers in this assay, from the lowest: compound 2; then compounds 1 and 3 (each within the scatter of the next).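

In this assay, going by these compounds alone, the exchange of 3-hydroxyphenyl for 2,4-dihydroxyphenyl on the carbon with a double bond to nitrogen comes to a number 1.8 percentage points higher from compound 1 to compound 3 (within the scatter) and is the first change at a single place that can be read directly. At this one position, then, the ring can carry a second hydroxyl group, and with it the extra hydrogen-bond donor and acceptor, with no change in the read-out that stands clear of the usual scatter, at least with both 4-chlorophenyl groups in place. Nothing measured here explains why this exchange leaves the number where it is.

Because the hydroxyl pattern changes as a whole in this step, the pair cannot say which hydroxyl group matters, or whether any is needed, and compound 2 differs from compound 1 in too many places to settle this. From the compounds shown here alone, it also remains open how a plain phenyl ring at this position would compare, or a phenyl ring carrying an amine or a carboxylic acid in place of the hydroxyl groups.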